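Replacing cyclopropylamino with piperidin-1-yl in compound 1

This account rests on a few compounds, and the source may have more. Where it says the series, first, only, none or still open, it means among the compounds named here.

In a functional assay on A549 cells (Homo sapiens) for inhibition, with a stated time of 72 h (on this read-out higher numbers stand for weaker inhibition and lower numbers for stronger inhibition), compound 1 (`O=C(Nc1ccccc1)Nc1nc(NC2CC2)cc(Sc2c[nH]c3ccccc23)n1`) gives > 50000 nM. Compound 1 thus stands at the limit of > 50000 nM in this assay, at which 1 of the 2 values shown sits, and this reading is a limit, not a number. Compound 2 (`Cc1cc(Cl)ccc1NC(=O)Nc1nc(NC2CC2)cc(Sc2c[nH]c3ccccc23)n1`) gives 31500 nM. Going by the values given here, the only measured step, an at least 1.5-fold lower number from compound 1 to compound 2 (0.20 log units; that floor lies within the scatter), comes from 4-chloro-2-methylphenyl in place of phenyl on an amide-type nitrogen, so it does not touch the place changed here.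

Compound 3 (`O=C(Nc1ccccc1)Nc1nc(Sc2c[nH]c3ccccc23)cc(N2CCCCC2)n1`) carries piperidin-1-yl in place of cyclopropylamino on an aromatic carbon. Among the compounds with values here, no step has been measured at that place, so no change beyond the scatter is expected in this assay, and another limit reading would be no surprise. The expected step is an at least 1.1-fold lower number from compound 1 to compound 3 (0.04 log units; that floor lies within the scatter). Compound 3 is estimated at 45000 nM, with an expected range of 20000 nM to 90000 nM.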

Compound 3, half-maximal inhibitory concentration: 33100 nM
Beside the measured number, compound 3's estimate is 1.4-fold (0.13 log units) above it; low and high end bracket the measured number.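

In this assay, this place on the aromatic carbon now has its first measured step, and the change gives an at least 1.5-fold lower number from compound 1 to compound 3 (0.17 log units; that floor lies within the scatter). The reading of compound 1 is a limit, not a number: the limit of > 50000 nM in this assay, at which 1 of the 3 values shown sits. The exchange of cyclopropylamino, with its hydrogen-bond donor, for piperidin-1-yl, with none, therefore still gives a measured number in compound 3, but it shows no gain beyond the scatter.

On these data alone, the true size of this step stays open, as the printed floor is all that compound 1 allows. Also open, as far as these compounds go, are how morpholin-4-yl, dimethylamino or a longer alkylamino chain would read at this place, and whether piperidin-1-yl combined with the 4-chloro-2-methylphenyl group would read differently from either change alone.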